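From a dimethylphenyl amide to an ethoxyphenyl amide

This account rests on a few compounds, and the source may have more. Where it says the series, first, only, none or still open, it means among the compounds named here.

Compound 1 `COc1ccc2c(=O)c(/C=C/C(=O)Nc3cc(C)ccc3C)coc2c1` carries a 2,5-dimethylphenyl group on the amide-type nitrogen of the shared core. In a functional assay on Huh-7 cells (Homo sapiens) for inhibition, read by MTT assay, with a stated time of 48 h (a higher number here means a weaker inhibitor, a lower number a stronger inhibitor), compound 1 gives 11100 nM, level with compound 2 `Cc1ccccc1NC(=O)/C=C/c1coc2cc(O)ccc2c1=O` at 11100 nM, and together these are the highest of the three numbers, while compound 3 `O=C(/C=C/c1coc2cc(O)ccc2c1=O)Nc1ccccc1` gives 3880 nM. Going by the values given here, the only single-place step measured is a 2.9-fold lower number from compound 2 to compound 3 (0.46 log units; beyond the scatter). Compound 4 `CCOc1ccc(NC(=O)/C=C/c2coc3cc(OC)ccc3c2=O)cc1` differs from compound 1 in that (4-ethoxyphenyl in place of 2,5-dimethylphenyl on an amide-type nitrogen). Among the compounds with values here, no measured pair exchanges these two groups, so the step from compound 2 to compound 3 bears on it only loosely, as the one case where the aryl group on the amide-type nitrogen changed. A modest move toward a lower number is therefore expected: a 1.9-fold lower number from compound 1 to compound 4 (0.27 log units; within the scatter). Compound 4 is estimated at 6000 nM, within 2500 nM to 15000 nM.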

Compound 4, half-maximal inhibitory concentration: 3230 nM
Compound 4: the middle estimate sits 1.9-fold (0.27 log units) above what was measured; low and high end bracket the measured number.
By their numbers in this assay, from the lowest: compounds 4 and 3 (each within the scatter of the next); then compounds 1 and 2 (each within the scatter of the next).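

On the core of compound 1, the group on the amide-type nitrogen also affects the result: replacing 2,5-dimethylphenyl with 4-ethoxyphenyl gives a 3.4-fold lower number from compound 1 to compound 4 (0.54 log units; beyond the scatter) in this assay, a step beyond the scatter. Going by these compounds alone, until now, the only such step had been the removal of a methyl group on the other core. No available evidence accounts for this step.

The compounds shown do not separate the loss of the two methyl groups from the arrival of the ethoxy group. They also leave open how an unsubstituted phenyl, a longer alkoxy chain or an amine would behave in this place on this core.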